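The compounds below may be only part of what the source reports. "The series", "measured", "known", "first", "only" and "open" are said of these compounds alone.

Measured so far:
compound 1 `CCCCNc1nc(-c2ccccc2)nc2c1nnn2Cc1ccccc1C(F)(F)F`, 6500000 nM
compound 2 `CNc1nc(-c2ccccc2)nc2c1nnn2Cc1ccccc1F`, 25000000 nM
compound 3 `COc1ccc(C(=O)Nc2nc(-c3ccccc3)nc3c2nnn3Cc2ccccc2Cl)cc1`, 20000000 nM

In an assay on isolated protein for binding affinity to adenosine receptor A1 (Bos taurus) (on this read-out lower numbers stand for stronger inhibition and higher numbers for weaker inhibition), compound 1 gives 6500000 nM, the lowest of the three numbers. Compound 3 gives 20000000 nM and compound 2 gives 25000000 nM; both gaps to compound 1 lie beyond the usual scatter, so compound 1 stands as the strongest binder of the set, though all three numbers are very weak.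

Compound 4 `CCCCNc1nc(-c2ccccc2)nc2c1nnn2Cc1ccccc1` differs from compound 1 by hydrogen in place of trifluoromethyl on an aromatic carbon. Going by the values given here, no measured pair covers this change, so its size is not fixed by the data. A small step toward a higher number, or none beyond the scatter, is expected in this assay. Compound 4 is expected to give 9000000 nM, with a range from 3000000 nM to 27000000 nM. This estimate means an expected step of a 1.4-fold higher number from compound 1 to compound 4 (0.14 log units; within the scatter).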

Compound 4, inhibition constant: 11000000 nM
For compound 4 the middle estimate is 1.2-fold (0.09 log units) below the measured one, within the range that was stated.
By their numbers in this assay, from the lowest: compounds 1, 4, 3 and 2 (each within the scatter of the next, the first and the last beyond it).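

In this assay, going by these compounds alone, the change from 2-(trifluoromethyl)phenyl to phenyl gives a 1.7-fold higher number from compound 1 to compound 4 (0.23 log units; within the scatter) and is the first single-place comparison. At this aromatic carbon, trifluoromethyl and hydrogen are not told apart by this read-out, so trifluoromethyl is not required for the weak binding seen with compound 1. No available evidence accounts for this result.

As far as these compounds go, whether a methoxy group or a nitrile on this carbon would separate from hydrogen remains open. So does whether the same swap would read alike with a different group on the shared core.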